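A few compounds are considered here, and "the series" means these few. Any claim that something is new, unique, unknown or untested is made for them only; others in the source may bear on it.

Measured so far in an assay on cells for antagonist activity at transient receptor potential cation channel subfamily V member 1 (Homo sapiens), read by FLIPR and calcium flux, with a stated time of 6 min; on this read-out lower numbers stand for stronger inhibition and higher numbers for weaker inhibition:

compound 1 `CCCN(CCC)c1nc(C(C)(C)C)ccc1CNC(=O)C(C)c1ccc(NS(C)(=O)=O)c(F)c1`: 2.5 nM
compound 2 `CCCCCCOc1nc(C(C)(C)C)ccc1CNC(=O)C(C)c1ccc(NS(C)(=O)=O)c(F)c1`: 2.7 nM
compound 3 `CC(C(=O)NCc1ccc(C(C)(C)C)nc1OC1CCCC1)c1ccc(NS(C)(=O)=O)c(F)c1`: 1.5 nM

Compound 1 sits second highest of the three numbers in this assay; compound 2 lies nearest to it and compound 3 furthest, and both gaps are within the usual scatter, so the three compounds are not separated by these data.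

The open compound is compound 4 `CC(C(=O)NCc1ccc(C(C)(C)C)nc1OCc1ccccc1)c1ccc(NS(C)(=O)=O)c(F)c1`. Relative to compound 1 the change is benzyloxy in place of dipropylamino on an aromatic carbon. Two measured steps start from the same dipropylamino on the same aromatic carbon: a 1.1-fold higher number from compound 1 to compound 2 (0.03 log units; within the scatter) and a 1.7-fold lower number from compound 1 to compound 3 (0.22 log units; within the scatter). A third step, a 1.8-fold lower number from compound 2 to compound 3 (0.26 log units; within the scatter), compares two of the oxygen-linked groups with each other. All three are within the scatter. Among the compounds with values here, replacing dipropylamino by an oxygen-linked group has so far left the number where it was, whether the group was a hexyl chain or a cyclopentyl ring; no compound goes against this, though only two such replacements exist. Benzyloxy has not been measured, so the size of its effect is not known from these data.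

On that basis the expected step is a 1.1-fold lower number from compound 1 to compound 4 (0.06 log units; within the scatter), that is, no step beyond the scatter. Compound 4 is therefore estimated at 2.2 nM in this assay, with a range from 0.9 nM to 5.5 nM.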

Compound 4, inhibition constant: 4.4 nM
Compound 4: the middle estimate sits 2.0-fold (0.30 log units) below what was measured; the measured number falls inside the stated range.
By their numbers in this assay, from the lowest: compounds 3, 1, 2 and 4 (each within the scatter of the next, the first and the last beyond it).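

In this assay, within the data shown here, benzyl in place of cyclopentyl on the oxygen gives the first step at this position that lies beyond the scatter (a 2.9-fold higher number from compound 3 to compound 4 (0.47 log units; beyond the scatter)), though it is modest, so the oxygen-linked groups can no longer all be treated as equivalent here. Among these compounds, compound 4 is not separated from the other two compounds (a 1.8-fold higher number from compound 1 to compound 4 (0.25 log units; within the scatter); a 1.6-fold higher number from compound 2 to compound 4 (0.21 log units; within the scatter)), so among the four compounds only the pair of compound 3 and compound 4 is resolved, and dipropylamino, hexyloxy and benzyloxy remain indistinguishable on this aromatic carbon. Nothing available accounts for the gap between cyclopentyloxy and benzyloxy.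

Still open, from the compounds shown here alone, is whether that gap follows the aromatic ring or the extra carbon between ring and oxygen, a question that phenoxy, cyclohexyloxy and cyclopentylmethoxy groups on the same aromatic carbon could address. Also open, going by these compounds, is whether a short chain such as ethoxy, or a cyclic amine such as morpholine in place of dipropylamino, would stay within the same narrow span of numbers.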